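A Second Chloro Enters the Benzyl Ring

A few compounds are considered here, and "the series" means these few. Any claim that something is new, unique, unknown or untested is made for them only; others in the source may bear on it.

Compound 3 `Cc1nn(-c2ncnc3nc[nH]c23)c2c1C(OCc1ccccc1Cl)CC(=O)N2` is one of three measured analogues that share a single core and differ only in the group on the oxygen on the saturated carbon. In a functional assay on HEK293 cells for agonist activity at G-protein coupled receptor 39 (Homo sapiens), read by scintillation proximity assay and inositol phosphate accumulation, with a stated time of 75 min (a lower number here means that less compound is needed, a higher number that more compound is needed for the effect), compound 3 gives 47 nM. Compound 1 `Cc1nn(-c2ncnc3nc[nH]c23)c2c1C(OC1CCCC1)CC(=O)N2` carries cyclopentyl at that oxygen and gives 62 nM in this assay, while compound 2 `Cc1nn(-c2ncnc3nc[nH]c23)c2c1C(OCc1cc(F)cc3c1OCOC3)CC(=O)N2` gives 30 nM. Compound 3 thus stands second highest of the three numbers, yet both of its neighbours sit within the scatter: a 1.3-fold lower number from compound 1 to compound 3 (0.12 log units; within the scatter) and a 1.6-fold higher number from compound 2 to compound 3 (0.19 log units; within the scatter). Across these three compounds, exchanging the group on that oxygen has not moved the number beyond the usual scatter.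

Compound 4 `Cc1nn(-c2ncnc3nc[nH]c23)c2c1C(OCc1ccc(Cl)cc1Cl)CC(=O)N2` differs from compound 3 in one place: chloro in place of hydrogen on an aromatic carbon. Among the compounds with values here, no measured step shows a chloro entering an aromatic ring on its own; the closest evidence is the pair of steps into compound 3, both within the scatter even though they swapped far larger groups. On that basis only a small step in this assay is expected, in no firm direction. Compound 4 is therefore estimated to give 40 nM, with a range from 15 nM to 110 nM. The expected step is a 1.2-fold lower number from compound 3 to compound 4 (0.07 log units; within the scatter), which is expected to stay within the scatter.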

Compound 4, half-maximal effective concentration: 243 nM
Estimate against measurement, compound 4: 6.1-fold (0.78 log units) below, and the stated range ends below it.
By their numbers in this assay, from the lowest: compounds 2, 3 and 1 (each within the scatter of the next, the first and the last beyond it); then compound 4.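

The chloro is the smallest change among these compounds, yet in this assay it brings a 5.2-fold higher number from compound 3 to compound 4 (0.71 log units; beyond the scatter), the first step beyond the scatter for a change on the benzyl ring, so this aromatic carbon, para to a large group, is a place where the number responds. The 2,4-dichlorobenzyl group also stands apart from the other groups on the oxygen, with an 8.1-fold higher number from compound 2 to compound 4 (0.91 log units; beyond the scatter) and a 3.9-fold higher number from compound 1 to compound 4 (0.59 log units; beyond the scatter), so the closeness of compounds 1, 2 and 3 despite their very different groups does not extend to compound 4. Nothing measured on these compounds accounts for this rise.

The compounds shown leave open whether the rise belongs to chloro itself or would also follow another group at this carbon, such as fluoro, methyl or methoxy. They also leave open whether a 4-chlorobenzyl group, with no chloro meta to the new one, would give the same rise, or whether the rise needs both chloro groups together.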